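The source may hold more compounds than are shown below. What is called first, only, known or untested is meant among the compounds shown, and "the series" means these compounds.

Compound 1 `O=C(/C=C/c1ccc(N2CCCC2)cc1)c1ccc(O)cc1`: in an assay on isolated protein for inhibition of DNA topoisomerase 1 (Homo sapiens), tested at 100 uM (a higher number here means a stronger effect of the compound at the concentration tested, a lower number a weaker effect), compound 1 gives 74.7%.
Compound 2 `O=C(/C=C/c1ccc(F)cc1)c1ccc(O)cc1O`: in this assay compound 2 gives 80.2%.

On these two numbers compound 2 stands at the upper end, yet the gap to compound 1 lies within the usual scatter of repeated measurements, so the two compounds are not told apart by the data. Compound 3 `O=C(/C=C/c1ccc(N2CCCC2)cc1)c1ccc(O)cc1O` keeps the core of compound 2 and differs from it in one place: pyrrolidin-1-yl in place of fluoro on an aromatic carbon. Going by the values given here, the group that enters is the one that compound 1 already carries, and compound 1 sits within the scatter of compound 2. Among the compounds with values here, no step between measured compounds joins this pair directly, so the expectation rests on those two numbers alone. In this assay the expected step is a number 2.2 percentage points lower from compound 2 to compound 3 (within the scatter), nothing beyond the scatter in either direction. For compound 3 the estimated value is 78%, with a range from 64% to 90%.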

Compound 3, a percentage reported as inhibition, at one concentration (the size of the read-out at that concentration, not a potency): 87.1%
Estimate against measurement, compound 3: 9.1 percentage points below; low and high end bracket the measured number.
By their numbers in this assay, from the lowest: compounds 1, 2 and 3 (each within the scatter of the next, the first and the last beyond it).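

On the aromatic carbon para to a large group, pyrrolidin-1-yl in place of fluoro gives a number 6.9 percentage points higher from compound 2 to compound 3 (within the scatter) in this assay, so the larger ring is accommodated here with no loss that the data can detect. Going by these compounds alone, with pyrrolidin-1-yl held fixed, hydroxy in place of hydrogen on an aromatic carbon gives a number 12.4 percentage points higher from compound 1 to compound 3 (beyond the scatter), the first step in this small set to pass beyond the scatter, though only a modest one. Nothing available explains the size of either step.

The compounds shown leave open whether dimethylamino, an open-chain amine, or a morpholine ring would serve at this carbon as pyrrolidin-1-yl does. They also leave open whether a methoxy group in place of the added hydroxy would preserve the second step.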